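Methoxy for Methyl on a Fused Core

The compounds below may be only part of what the source reports. "The series", "measured", "known", "first", "only" and "open" are said of these compounds alone.

Measured so far:
compound 1 `Cc1cc(O)nc(NC(=S)NC(=O)c2c(-c3ccc(Cl)cc3Cl)noc2C)n1` — 46.8%
compound 2 `CSc1cc(C)nc(NC(=S)NC(=O)c2c(-c3ccc(Cl)cc3Cl)noc2C)n1` — 47.1%
compound 3 `Cc1onc(-c2ccc(Cl)cc2Cl)c1C(=O)/N=c1/nc2nc(Cl)cc(C)n2s1` — 55.6%

In a functional assay on the whole organism (strain L.) for inhibition, with Echinochloa crus-galli as the target, with a stated time of 72 h, tested at 100 mg/L (on this read-out higher numbers stand for more inhibition of growth at the one concentration tested and lower numbers for less inhibition of growth), compound 3 gives the largest of the three numbers, yet its gaps to compound 2 and compound 1 are both within the scatter, so it cannot be called the most active. Within the data shown here, the only step measured in this set, a number 0.3 percentage points higher from compound 1 to compound 2 (within the scatter), exchanges one group on the shared core and changes nothing beyond the scatter. Compound 4 `COc1cc(Cl)nc2n/c(=N/C(=O)c3c(-c4ccc(Cl)cc4Cl)noc3C)sn12` differs from compound 3 by methoxy in place of methyl on an aromatic carbon. Among the measured compounds shown here, no measured step touches that position or that exchange, so nothing points to a direction. The step expected from this change is a number 1.6 percentage points lower from compound 3 to compound 4 (within the scatter), none beyond the scatter. Compound 4 is therefore estimated at 54%, with a range from 36% to 72%.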

Compound 4, percent growth inhibition at one concentration: 40.8%
Estimate against measurement, compound 4: 13.2 percentage points above; low and high end bracket the measured number.
By their numbers in this assay, from the lowest: compounds 4, 1, 2 and 3 (each within the scatter of the next, the first and the last beyond it).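

Among these compounds, this position on the shared core does respond to a change of group: in this assay methoxy in place of methyl gives a number 14.8 percentage points lower from compound 3 to compound 4 (beyond the scatter) and is the first step in the set to pass beyond the scatter. Among the compounds shown here, the only earlier step, made on the core of compound 1, showed no such shift. No measurement available here gives a reason for this loss. The compounds shown leave open how an amine or an ethyl group at this position would compare, and so whether the loss belongs to methoxy alone.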